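This account rests on a few compounds, and the source may have more. Where it says the series, first, only, none or still open, it means among the compounds named here.

Among the compounds with values here, compound 3 `CCCOc1ccc(NC(=O)CCCCCCCSc2nnc(Cc3nn(C)c(=O)c4ccccc34)n2C)cc1` gives 1600 nM in an assay on isolated protein (Mus musculus) for inhibition of IL15-IL15 receptor (Homo sapiens), read by resazurin assay, with stated times of 30 min and 2.5 days (a lower number here means a stronger inhibitor, a higher number a weaker inhibitor), and stands second highest of the three numbers measured so far; its nearest neighbour is compound 1 `Cn1c(Cc2nn(C)c(=O)c3ccccc23)nnc1SCCCCCCCC(=O)Nc1ccc(Br)cc1Br` at 1500 nM, its furthest compound 2 `Cc1ccc(NC(=O)CCCCCCCSc2nnc(Cc3nn(C)c(=O)c4ccccc34)n2C)c(Cl)c1` at 2300 nM. The measured steps are a 1.1-fold higher number from compound 1 to compound 3 (0.03 log units; within the scatter), a 1.4-fold lower number from compound 2 to compound 3 (0.16 log units; within the scatter) and a 1.5-fold higher number from compound 1 to compound 2 (0.19 log units; within the scatter), each a swap of one aryl group on the amide-type nitrogen and each within the scatter. Compound 4 `Cn1c(Cc2nn(C)c(=O)c3ccccc23)nnc1SCCCCCCCC(=O)Nc1ccc(O)cc1O` continues the same kind of change: 2,4-dihydroxyphenyl in place of 4-propoxyphenyl on an amide-type nitrogen. Within the data shown here, none of the measured steps brought in hydrogen-bond donors at this position, so they bear on compound 4 only loosely, yet they point to a flat response. The expected step is therefore small, a 1.1-fold higher number from compound 3 to compound 4 (0.05 log units; within the scatter). Compound 4 is expected near 1800 nM, with an estimated range from 700 nM to 4500 nM.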

Compound 4, half-maximal inhibitory concentration: 17000 nM
For compound 4 the middle estimate is 9.4-fold (0.98 log units) below the measured one; measured number above the stated range.
By their numbers in this assay, from the lowest: compounds 1, 3 and 2 (each within the scatter of the next); then compound 4.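

Within the data shown here, the aryl group on the amide-type nitrogen is not as tolerant as the earlier swaps suggested: 2,4-dihydroxyphenyl is the first group here to move the number beyond the scatter (an 11-fold higher number from compound 3 to compound 4 (1.03 log units; beyond the scatter)). The loss holds against 2-chloro-4-methylphenyl (a 7.4-fold higher number from compound 2 to compound 4 (0.87 log units; beyond the scatter)) and 2,4-dibromophenyl (an 11-fold higher number from compound 1 to compound 4 (1.05 log units; beyond the scatter)), leaving compound 4 the weakest of the series. Nothing available explains this loss.

On these data alone, whether one hydroxyl or both carry the loss remains open, as 4-hydroxyphenyl and 2-hydroxyphenyl analogues would separate them. Also open, as far as these compounds go, is how a methoxy group, an amine or a carboxylic acid on this ring would behave.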